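This account rests on a few compounds, and the source may have more. Where it says the series, first, only, none or still open, it means among the compounds named here.

Of the compounds shown here, three sharing one core have been tested in a physicochemical assay, with a stated time of 6 min; a lower number here means a stronger inhibitor, a higher number a weaker inhibitor. Compound 1 `Cc1ccc(NC(=O)Nc2nc(-c3cc4cc(Br)ccc4o3)cs2)cc1` gave only a limit of the assay, > 200000 nM. Compound 2 `O=C(Nc1ccccc1)Nc1nc(-c2cc3cc([N+](=O)[O-])ccc3o2)cs1` gives 183000 nM, the higher of the two actual numbers, which makes it a weak inhibitor here. Compound 3 `O=C(Nc1cccc(Cl)c1)Nc1nc(-c2cc3ccccc3o2)cs1` gives 14100 nM, the number nearest to that of compound 2 and clearly lower.

Compound 4 `O=C(Nc1ccc(F)cc1)Nc1nc(-c2cc3cc([N+](=O)[O-])ccc3o2)cs1` has not yet been measured. It differs from compound 2 in a single place: fluoro in place of hydrogen on an aromatic carbon. In words, this is fluoro in place of hydrogen on an aromatic carbon, para to a large group, so that phenyl becomes 4-fluorophenyl.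

Among the compounds with values here, no two measured compounds differ by one change alone, so the data give no direct guide to the size of such a step. The starting point is therefore compound 2 at 183000 nM, and no shift beyond the usual scatter is expected in either direction. The expected change is a 1.4-fold lower number from compound 2 to compound 4 (0.15 log units; within the scatter). For compound 4 the estimated value is 130000 nM, with an expected range of 40000 nM to 200000 nM.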

Compound 4, half-maximal inhibitory concentration: 123000 nM
Estimate against measurement, compound 4: 1.1-fold (0.02 log units) above, within the range that was stated.
By their numbers in this assay, from the lowest: compound 3; then compounds 4 and 2 (each within the scatter of the next). At a limit, above all of these: compound 1.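

In this assay, within the data shown here, fluoro in place of hydrogen on an aromatic carbon, para to a large group, turns phenyl into 4-fluorophenyl and gives a 1.5-fold lower number from compound 2 to compound 4 (0.17 log units; within the scatter), the first single change that can be read directly. The step lies within the scatter, so at this position fluoro and hydrogen cannot be told apart in this assay, and compound 2 and compound 4 are both weak inhibitors. Compound 1 gives only a limit and not a number, so it offers no comparison: the limit of > 200000 nM in this assay, at which 1 of the 4 values shown sits.

As far as these compounds go, whether a different group at this position, such as an amine or a carboxylic acid, would shift the number beyond the scatter remains open. Compound 3 differs from compound 2 in more than one place, so the compounds shown do not tell which part of the structure goes with its lower number.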